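This account rests on a few compounds, and the source may have more. Where it says the series, first, only, none or still open, it means among the compounds named here.

Compound 1 `COc1ccc2c(C(=O)/C(C#N)=C/c3cn(Cc4ccc(Cl)cc4)c4ccccc34)c[nH]c2c1`: > 50000 nM, a limit and not a number.
Compound 2 `COc1ccc2c(C(=O)/C(C#N)=C/c3c[nH]c4ccccc34)c[nH]c2c1`: 6400 nM.

Both entries come from a functional assay on A549 cells (Homo sapiens) for cytotoxicity, read by WST assay, with a stated time of 24 h; on this read-out lower numbers stand for stronger inhibition and higher numbers for weaker inhibition. Among the compounds with values here, compound 2 holds the only true number so far, so there is no spread of numbers to place it in.

Compound 3 `COc1ccc(Cn2cc(/C=C(\C#N)C(=O)c3c[nH]c4cc(OC)ccc34)c3ccccc32)cc1` is next, with 4-methoxybenzyl in place of hydrogen on an aromatic nitrogen.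

Within the data shown here, one measured step bears on this change: an at least 7.8-fold lower number from compound 1 to compound 2 (0.89 log units; beyond the scatter). There, hydrogen took the place of 4-chlorobenzyl on an aromatic nitrogen, so compound 3 runs the same kind of exchange in reverse, with a different benzyl group. A higher number is therefore expected in this assay, beyond the scatter, though this rests on a single pair. The expected change is a 6.3-fold higher number from compound 2 to compound 3 (0.80 log units; beyond the scatter). Compound 3 may also return only a limit. For compound 3 the estimate is 40000 nM, with an expected range of 15000 nM to 100000 nM.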

Compound 3, half-maximal inhibitory concentration: 37400 nM
Estimate against measurement, compound 3: 1.1-fold (0.03 log units) above; the range from low to high includes it.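

With 4-methoxybenzyl in place of hydrogen on an aromatic nitrogen, this assay now gives this change a measured size: a 5.8-fold higher number from compound 2 to compound 3 (0.77 log units; beyond the scatter). Within the data shown here, until now, the only benzyl compound at this position stood at a limit, whereas here both ends of the step are true numbers, and the number with hydrogen on this nitrogen is the lower one. The exchange of methoxy in place of chloro on an aromatic carbon gives an at least 1.3-fold lower number from compound 1 to compound 3 (0.12 log units; that floor lies within the scatter). This step cannot be read further, as one of its ends is a limit: the limit of > 50000 nM in this assay, at which 1 of the 3 values shown sits.

On these data alone, whether any group on this nitrogen raises the number, or only benzyl groups do, remains open; a methyl, a short chain ending in an amine, or an acetic acid side chain there would help separate the two. Changes elsewhere on the shared core also remain untested in this set.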